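Chain extension on the amide in a benzamide series

The source may report more compounds than this note shows. Statements on the series, on what has been measured and on what is new or still open speak of the compounds shown alone.

Compound 1 `COc1cc(N)c(Cl)cc1C(=O)NC1CCN(CC2CCN(CCCCN)CC2)CC1` and compound 2 `COc1cc(N)c(Cl)cc1C(=O)NC1CCN(CC2CCN(C(=O)CN)CC2)CC1` share one core and differ only at the amine nitrogen of the outer ring. In an assay on striatum for inhibition of 5-hydroxytryptamine receptor 4 (Cavia porcellus), read by radioligand binding (a lower number here means a stronger inhibitor, a higher number a weaker inhibitor), compound 1 gives 6.47 nM, and in the same assay compound 2 gives 9.3 nM. The step of a 1.4-fold higher number from compound 1 to compound 2 (0.16 log units; within the scatter) shows that the two numbers cannot be told apart, so compound 2 stands level with compound 1 and neither can be called the stronger.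

Compound 3 `COc1cc(N)c(Cl)cc1C(=O)NC1CCN(CC2CCN(C(=O)CCN)CC2)CC1` keeps the carbonyl on that ring nitrogen and carries the change (aminomethyl in place of amino on a saturated chain carbon bound to a carbonyl carbon), an aminomethyl in place of amino on a saturated chain carbon bound to a carbonyl carbon. Within the data shown here, no measured step lengthens this chain by one carbon; the only step available, from compound 1 to compound 2, replaces a whole chain with a carbonyl-bearing group and stays within the scatter. A one-carbon extension is therefore expected to give a step no larger than the scatter, a 1.0-fold lower number from compound 2 to compound 3 (0.01 log units; within the scatter), in this assay. Compound 3 is expected to give about 9 nM, within 4 nM to 25 nM.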

Compound 3, half-maximal inhibitory concentration: 9.5 nM
The estimate for compound 3 lay 1.1-fold (0.02 log units) below the measured number; the measured number falls inside the stated range.
By their numbers in this assay, from the lowest: compounds 1, 2 and 3 (each within the scatter of the next).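

In this assay, among these compounds, the one-carbon extension, aminomethyl in place of amino on a saturated chain carbon bound to a carbonyl carbon, gives a 1.0-fold higher number from compound 2 to compound 3 (0.01 log units; within the scatter) and is the first step at this position to change chain length alone, so at this length the added carbon cannot be told from no change at all. The wider replacement of the whole chain on the ring nitrogen gives a 1.5-fold higher number from compound 1 to compound 3 (0.17 log units; within the scatter) and so also cannot be read as a difference, which leaves compound 1, compound 2 and compound 3 level at this ring nitrogen with either chain. Nothing on hand offers a reason why these chains read alike.

As far as these compounds go, all three compounds end in a primary amine, so it stays open whether a carboxylic acid, a hydroxyl or a dimethylamino group at the chain end would stay level with them. Also open, from the compounds shown here alone, is whether a longer chain on the carbonyl, such as 3-aminopropyl or 4-aminobutyl, would still read the same in this assay as the two shorter ones.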